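The source may hold more compounds than are shown below. What is called first, only, known or untested is meant among the compounds shown, and "the series" means these compounds.

Working notes on the series. In a functional assay on cells (blood, Homo sapiens) for inhibition, read by chemiluminescence, with a stated time of 30 min (on this read-out higher numbers stand for weaker inhibition and lower numbers for stronger inhibition), compound 1 `CC1(C)CC(=O)C(C(=S)SCc2ccccc2)=C(Nc2ccc(Cl)cc2Cl)C1` returns only a limit, > 100 ug/mL. Compound 2 `CC(=O)OC[C@H]1O[C@@H](SC(=S)C2=C(Nc3ccc(Cl)cc3Cl)CC(C)(C)CC2=O)[C@H](OC(C)=O)[C@@H](OC(C)=O)[C@@H]1OC(C)=O` likewise returns only a limit in this assay, > 100 ug/mL. For the measured compounds named here, compound 3 `CC(=O)OC[C@H]1O[C@@H](SC(=S)C2=C(Nc3ccc(Cl)cc3)CC(C)(C)CC2=O)[C@H](OC(C)=O)[C@@H](OC(C)=O)[C@@H]1OC(C)=O` is the one compound with an actual number in this assay, 90 ug/mL. Going by the values given here, it therefore stands as the single measured value in this assay, while the other two compounds give no number. Among the compounds with values here, the one measured step is an at least 1.1-fold lower number from compound 2 to compound 3 (0.04 log units; that floor lies within the scatter), hydrogen in place of chloro on an aromatic carbon; its floor lies within the scatter and is set by the limit of > 100 ug/mL in this assay, at which 2 of the 3 values shown sit, so the size of that step is unknown beyond its lower bound.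

Compound 4 `CC(=O)OC[C@H]1O[C@@H](SC(=S)C2=C(Nc3ccc(Br)cc3)CC(C)(C)CC2=O)[C@H](OC(C)=O)[C@@H](OC(C)=O)[C@@H]1OC(C)=O` differs from compound 3 by bromo in place of chloro on an aromatic carbon. Within the data shown here, no measured step exchanges one halogen for another, so the only bearing comes from the halogen removal above, which is not resolved beyond the scatter. The step of no change at the digits printed from compound 3 to compound 4 (within the scatter) in this assay is therefore expected to stay within the scatter, with a real chance that only a limit is reported. Compound 4 is estimated at 90 ug/mL, with a range from 45 ug/mL to 180 ug/mL.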

Compound 4, half-maximal inhibitory concentration: > 100 ug/mL
Compound 4: a limit, no number; the forecaster's own chance of this, stated with the estimate: 45%; at least 1.1-fold (0.04 log units) between middle value and limit.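

Bromo in place of chloro, on an aromatic carbon para to a large group, gives the first direct exchange of one halogen for another in this assay: an at least 1.1-fold higher number from compound 3 to compound 4 (0.04 log units; that floor lies within the scatter). For the compounds shown here, compound 3, at 90 ug/mL, remains the only compound with a number, so this result does not resolve a difference between the two halogens at this position. The other new step, 4-bromophenyl in place of 2,4-dichlorophenyl on an amine nitrogen, cannot be read, and the series now rests largely on a limit: the limit of > 100 ug/mL in this assay, at which 3 of the 4 values shown sit.

Going by these compounds, the true size of the step from chloro to bromo stays open. Also open, on these data alone, is whether an amine or a carboxylic acid on the same aromatic carbon would give a number clear of that limit.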